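Fluoro to chloro on two enone cores in CCRF-CEM cells

A few compounds are considered here, and "the series" means these few. Any claim that something is new, unique, unknown or untested is made for them only; others in the source may bear on it.

Measured compounds:
compound 1 `O=C1/C(=C/c2ccc(F)cc2)Cc2ccccc21`, 42200 nM
compound 2 `O=C1/C(=C/c2ccc(Cl)cc2)Cc2ccccc21`, 284000 nM
compound 3 `O=C1CCCCC/C1=C\c1ccc(F)cc1`, 198000 nM

In a functional assay on CCRF-CEM cells (Homo sapiens) for inhibition (a higher number here means a weaker inhibitor, a lower number a stronger inhibitor), compound 1 gives 42200 nM and compound 2 gives 284000 nM. Compound 2 differs from compound 1 by chloro in place of fluoro on an aromatic carbon, and this step is a 6.7-fold higher number from compound 1 to compound 2 (0.83 log units; beyond the scatter). Compound 3, built on a different core, gives 198000 nM in this assay; the difference between the two cores is not broken down here. Compound 4 `O=C1CCCCC/C1=C\c1ccc(Cl)cc1` is not yet measured. It differs from compound 3 by chloro in place of fluoro on an aromatic carbon, the same kind of change as from compound 1 to compound 2, though here the place is para to a group of 9 heavy atoms rather than para to a large group. Because compound 1 to compound 2 showed a 6.7-fold higher number from compound 1 to compound 2 (0.83 log units; beyond the scatter), the author expects a step of a 4.5-fold higher number from compound 3 to compound 4 (0.66 log units; beyond the scatter) for compound 4. Compound 4 is therefore estimated at 900000 nM, between 250000 nM and 3000000 nM.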

Compound 4, half-maximal inhibitory concentration: 43500 nM
Estimate against measurement, compound 4: 21-fold (1.32 log units) above; measured number outside the range, below it.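

In this assay, replacing fluoro with chloro on the aromatic carbon gives a 4.6-fold lower number from compound 3 to compound 4 (0.66 log units; beyond the scatter), so the direction of the earlier step did not carry over from one core to the other. Set side by side, the two steps run in opposite directions: the same change on two cores in this assay, a 6.7-fold higher number (0.83 log units; beyond the scatter) from compound 1 to compound 2 and a 4.6-fold lower number (0.66 log units; beyond the scatter) from compound 3 to compound 4, 31-fold (1.49 log units) apart, beyond the scatter of two such steps. These two pairs show that the effect of this change in this series depends on the core, but they do not show which feature of the core is responsible or what the change would do on any further core.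

The compounds shown leave open whether bromo or methoxy in place of chloro would follow the same opposite trends on the two cores. They also leave open how an amine on the aromatic ring would behave on either core.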